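Swapping a Saturated Chain for an Alkene Chain

The source may report more compounds than this note shows. Statements on the series, on what has been measured and on what is new or still open speak of the compounds shown alone.

Compound 1, `Cc1ccc(-c2c3c(nc(C)c2[C@H](OC(C)(C)C)C(=O)O)CCN(CCCc2ccccc2)C3)cc1`, carries a 3-phenylpropyl chain on an amine nitrogen in a ring of its shared core. In an ADME assay on MT2 cells (Homo sapiens) for cytotoxicity, read by XTT assay, with a stated time of 4 days (on this read-out lower numbers stand for higher toxicity in this test and higher numbers for lower toxicity in this test), compound 1 gives > 40000 nM, which is a limit of the assay rather than a number. A second compound, compound 2 with structure `Cc1ccc(-c2c3c(nc(C)c2C(OC(C)(C)C)C(=O)O)CCN(C)C3)cc1`, carries a much shorter substituent on that ring nitrogen. In this assay compound 2 gives > 40000 nM, again a limit rather than a number. Within the data shown here, compound 1 thus stands at the limit of > 40000 nM in this assay, at which 2 of the 2 values shown sit, so neither measured compound shows toxicity within the tested range, and no step between measured compounds can be sized.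

Compound 3, `Cc1ccc(-c2c3c(nc(C)c2[C@H](OC(C)(C)C)C(=O)O)CCN(C/C=C/c2ccccc2)C3)cc1`, has not yet been measured. It differs from compound 1 in one place: 2-phenylethenyl in place of phenethyl on a saturated chain carbon bound to an amine nitrogen in a ring. The change adds one double bond outside aromatic rings and nothing else. With both measured compounds sitting at the limit, no step beyond the usual scatter is expected here. Compound 3 is therefore expected to give 40000 nM, ranging from 20000 nM to 80000 nM. The step this implies, a number no higher from compound 1 to compound 3 (the limit leaves the size open), is expected to be essentially none.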

Compound 3, half-maximal cytotoxic concentration: > 40000 nM
Compound 3 was reported as a limit (the forecaster's own chance of this, stated with the estimate: 85%); the middle value lies on the limit itself.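

No step can be read from compound 1 to compound 3, because each value is a limit of the assay and not a number: the limit of > 40000 nM in this assay, at which 3 of the 3 values shown sit. The compounds shown leave open whether the saturated chain and the alkene chain differ in toxicity at all, and at what concentration, if any, toxicity would appear.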